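The source may hold more compounds than are shown below. What is called first, only, known or untested is meant among the compounds shown, and "the series" means these compounds.

In a functional assay with Felis catus as the target (on this read-out higher numbers stand for an effect only at larger amounts of compound and lower numbers for an effect already at smaller amounts), compound 1 `Cc1nc(O)c(C#N)c(NCc2ccco2)n1` gives 88000 nM and compound 2 `CCc1nc(O)c(C#N)c(NCc2cccnc2)n1` gives 86000 nM as the read-out, while compound 3 `CC(C)c1nc(O)c(C#N)c(NCc2cccnc2)n1` gives 10000 nM and so stands lowest of the three, beyond the scatter from both. Compound 4 `CC(C)(C)c1nc(O)c(C#N)c(NCc2cccnc2)n1` remains unmeasured. Its change from compound 3 is methyl in place of hydrogen on a saturated chain carbon bound to an aromatic carbon and two saturated chain carbons and reads in words as methyl in place of hydrogen on a saturated chain carbon bound to an aromatic carbon and two saturated chain carbons, or isopropyl to tert-butyl. Among the compounds with values here, the one measured step that bears on it is an 8.6-fold lower number from compound 2 to compound 3 (0.93 log units; beyond the scatter) and it is modest but beyond the scatter, for methyl in place of hydrogen on a saturated chain carbon bound to an aromatic carbon and a saturated chain carbon. That is a single step, so no trend is established, and nothing measured yet shows how the series responds to this further methyl. A further move in the same direction is expected in this assay but a smaller one, and a reversal cannot be ruled out. The expected size is a 2.2-fold lower number from compound 3 to compound 4 (0.35 log units; beyond the scatter) as an estimate only. For compound 4 the estimated value is 4500 nM with an expected range from 1000 nM to 25000 nM in repeat measurements.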

Compound 4, half-maximal effective concentration: 110000 nM
Compound 4: middle estimate off by 24-fold (1.39 log units), on the low side, outside the stated range (above it).
By their numbers in this assay, from the lowest: compound 3; then compounds 2, 1 and 4 (each within the scatter of the next).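

In this assay, the methyl on this carbon does not repeat what the previous methyl did: an 8.6-fold lower number from compound 2 to compound 3 (0.93 log units; beyond the scatter) is followed by an 11-fold higher number from compound 3 to compound 4 (1.04 log units; beyond the scatter), so the same kind of change at this position runs in opposite directions, depending on whether the carbon goes from ethyl to isopropyl or from isopropyl to tert-butyl. With a 1.3-fold higher number from compound 2 to compound 4 (0.11 log units; within the scatter), the ethyl of compound 2 and the tert-butyl of compound 4 cannot be told apart, which leaves the isopropyl of compound 3 as a single low point among these three rather than one end of a steady trend. The data shown give no measured basis for explaining this turn.

On these data alone, whether the low number belongs to isopropyl alone remains open, since cyclopropyl or a straight propyl chain on the same aromatic carbon would test how narrow this optimum is. The part of the structure that separates compound 1 from the others also differs together with the chain, so its separate contribution cannot be read from the compounds shown.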